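Chloro in Place of Fluoro on a Phenylamino Group

The source may report more compounds than this note shows. Statements on the series, on what has been measured and on what is new or still open speak of the compounds shown alone.

Compound 1 `O=C(CSc1nc(Nc2ccccc2)c2ccccc2n1)Nc1ccc(Cl)c(Cl)c1` and compound 2 `O=C(CSc1nc(Nc2ccccc2)c2ccccc2n1)Nc1ccc(F)c(Cl)c1` share one core, while compound 3 `C=CC(=O)Nc1cccc(NC(=O)CSc2nc(Nc3ccc(F)cc3)c3ccccc3n2)c1` is built on another; the difference between the two cores is not broken down here. In a functional assay on MGC-803 cells (Homo sapiens) for inhibition, read by MTT assay, with a stated time of 72 h (on this read-out higher numbers stand for weaker inhibition and lower numbers for stronger inhibition), compound 1 gives 37900 nM, compound 2 gives 20900 nM, and compound 3 gives 8290 nM, the lowest of the three. Between compound 2 and compound 1 the change is chloro in place of fluoro on an aromatic carbon, and it brings a 1.8-fold higher number from compound 2 to compound 1 (0.26 log units; within the scatter). Compound 4 `C=CC(=O)Nc1cccc(NC(=O)CSc2nc(Nc3ccc(Cl)cc3)c3ccccc3n2)c1` has not been measured; from compound 3 it differs by chloro in place of fluoro on an aromatic carbon. This is the same kind of change, though in compound 1 the carbon in question is also ortho to a chloro group, which compound 4 lacks. The expectation for compound 4 rests on the step of a 1.8-fold higher number from compound 2 to compound 1 (0.26 log units; within the scatter), which stayed within scatter, and on compound 3 at 8290 nM. Compound 4 is therefore expected to move only by a 1.2-fold higher number from compound 3 to compound 4 (0.08 log units; within the scatter). Compound 4 is estimated at 10000 nM, most likely between 4000 nM and 25000 nM.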

Compound 4, half-maximal inhibitory concentration: 14300 nM
For compound 4 the middle estimate is 1.4-fold (0.16 log units) below the measured one, and the stated range covers the measured number.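

In this assay, chloro in place of fluoro on an aromatic carbon gives a 1.7-fold higher number from compound 3 to compound 4 (0.24 log units; within the scatter), and set beside the earlier step on the other core, the two agree: the same change on two cores in this assay, a 1.8-fold higher number (0.26 log units; within the scatter) from compound 2 to compound 1 and a 1.7-fold higher number (0.24 log units; within the scatter) from compound 3 to compound 4, 1.1-fold (0.02 log units) apart, within the scatter of two such steps. Across these two cores, then, the change carried over in the same way, with each step too small to be told apart from repeat measurements. Within the data shown here, this does not establish a real effect of shared size, as it rests on only two pairs of compounds, and compound 1 also carries a second chloro group on the ring that holds the change, which compound 4 lacks.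

The compounds shown leave open what a group other than a halogen, such as a methoxy group, an amine or a carboxylic acid, would do in place of the fluoro or chloro on the phenylamino group of compound 3. They also leave open whether bromo, a larger halogen, would fit the same picture on either core.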